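A few compounds are considered here, and "the series" means these few. Any claim that something is new, unique, unknown or untested is made for them only; others in the source may bear on it.

Measured in a functional assay on the whole organism (strain STD-dd) with Mus musculus as the target, in the maximal electroshock model, with a stated time of 2 h; a lower number here means that less compound is needed, a higher number that more compound is needed for the effect:

Compound 1 `CCNS(=O)(=O)Cc1noc2ccc(F)cc12`: 32 mg/kg
Compound 2 `CC(C)NS(=O)(=O)Cc1noc2ccc(F)cc12`: 38 mg/kg
Compound 3 `CNS(=O)(=O)Cc1noc2ccc(Br)cc12`: 15 mg/kg

Compound 1 and compound 2 share a core and differ by methyl in place of hydrogen on a saturated chain carbon bound to a saturated chain carbon and a sulfonamide nitrogen; this step gave a 1.2-fold higher number from compound 1 to compound 2 (0.07 log units; within the scatter). Compound 3 carries a different core, and the difference between the two cores is not broken down here. Compound 3 gives the lowest number of the three in this assay.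

Compound 4 `CCNS(=O)(=O)Cc1noc2ccc(Br)cc12` is not yet measured. It differs from compound 3 by methyl in place of hydrogen on a saturated chain carbon bound to a sulfonamide nitrogen. This is the same kind of change as that from compound 1 to compound 2, though the place differs: there the carbon is bound to a saturated chain carbon and a sulfonamide nitrogen, here only to a sulfonamide nitrogen. Since the earlier step was within the scatter, the step from compound 3 to compound 4 is expected to be small as well, about a 1.1-fold higher number from compound 3 to compound 4 (0.05 log units; within the scatter). In this assay compound 4 is estimated at 17 mg/kg, likely between 9 mg/kg and 32 mg/kg.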

Compound 4, dose for half-maximal effect: 18 mg/kg
For compound 4 the middle estimate is 1.1-fold (0.02 log units) below the measured one; low and high end bracket the measured number.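

In this assay, adding a methyl to the chain on the sulfonamide nitrogen gives steps that match on the two cores: the same change on two cores in this assay, a 1.2-fold higher number (0.07 log units; within the scatter) from compound 1 to compound 2 and a 1.2-fold higher number (0.08 log units; within the scatter) from compound 3 to compound 4, 1.0-fold (0.00 log units) apart, within the scatter of two such steps. The new step is a 1.2-fold higher number from compound 3 to compound 4 (0.08 log units; within the scatter), while bromo in place of fluoro with the ethyl chain kept gives a 1.8-fold lower number from compound 1 to compound 4 (0.25 log units; within the scatter). For the compounds shown here, with one small step per core, at carbons bound differently, this shows only that the change stays within the scatter in these two pairs; it does not show that it would carry over to other cores or other places.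

Butyl or longer chains on the sulfonamide nitrogen remain open. So do chloro or methoxy in place of the ring halogen.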